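The source may hold more compounds than are shown below. What is called first, only, known or untested is meant among the compounds shown, and "the series" means these compounds.

Measured so far:
- compound 1, `CCCc1cc(N)c2cc(NC(=O)/C=C/c3ccc(CC)cc3)ccc2n1`, 1.4 nM
- compound 2, `CCCc1cc(NC)c2cc(NC(=O)/C=C/c3ccc(C(F)(F)F)cc3)ccc2n1`, 1.5 nM
- compound 3, `Cc1cc(N)c2cc(NC(=O)/C=C/c3ccc(C(F)(F)F)cc3)ccc2n1`, 8 nM

In an assay on isolated protein for displacement of a labelled ligand from melanin-concentrating hormone receptor 1 (Homo sapiens) (a higher number here means a weaker inhibitor, a lower number a stronger inhibitor), compound 1 gives the lowest of the three numbers. Compound 2 sits within the scatter of compound 1, so no order between these two can be drawn. Compound 3 lies beyond the scatter, with a higher number than compound 1; compound 3 also differs from compound 1 in more than one place, so no single step can be read from that pair.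

Compound 4, `CCCc1cc(N)c2cc(NC(=O)/C=C/c3ccc(I)cc3)ccc2n1`, is not yet measured. It follows from compound 1 by one change: iodo in place of ethyl on an aromatic carbon. The group that leaves and the group that enters are both without donors or acceptors and without charge, and the pair in hand that also varies this position on the phenyl ring, compound 1 against compound 2, shows values within the scatter of each other. On that basis the step from compound 1 to compound 4 in this assay is expected to be small, a 1.4-fold higher number from compound 1 to compound 4 (0.15 log units; within the scatter), with no direction beyond the scatter claimed. Compound 4 is estimated at 2 nM, in the range 0.7 nM to 6 nM.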

Compound 4, half-maximal inhibitory concentration: 2.3 nM
For compound 4 the middle estimate is 1.2-fold (0.06 log units) below the measured one; measured number inside the range.
By their numbers in this assay, from the lowest: compounds 1, 2 and 4 (each within the scatter of the next); then compound 3.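

The series now holds its first step that changes one place only: in this assay, iodo in place of ethyl on an aromatic carbon gives a 1.6-fold higher number from compound 1 to compound 4 (0.22 log units; within the scatter). At this position, a single iodine atom thus stands in for the two carbons of ethyl with no change that can be read beyond the scatter. Nothing at hand gives a measured reason for this result.

Still open, on these data alone, is how this position responds to groups unlike ethyl and iodo, such as an amine, a carboxylic acid or a longer chain like hexyl. The propyl and methyl chains on the core, and amino against methylamino, also remain unseparated, as no pair shown differs in only one of these.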